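This account rests on a few compounds, and the source may have more. Where it says the series, first, only, none or still open, it means among the compounds named here.

In a functional assay on HCT-15 cells (Homo sapiens) for cytotoxicity, read by CCK-8 assay and cell counting, with a stated time of 2 days (on this read-out lower numbers stand for stronger inhibition and higher numbers for weaker inhibition), compound 1, built as `Oc1ccc(-c2cc(-c3ccsc3)nc(-c3cccc(Cl)c3)c2)cc1`, gives 5760 nM. Compound 2, built as `Oc1ccc(-c2cc(-c3cccc(Cl)c3)nc(-c3ccco3)c2)cc1`, gives 8020 nM in this assay. Within the data shown here, the one change between them is furan-2-yl in place of thiophen-3-yl on an aromatic carbon, and it made a 1.4-fold higher number from compound 1 to compound 2 (0.14 log units; within the scatter). Compound 3, built as `Oc1cccc(-c2cc(-c3ccsc3)nc(-c3ccccc3Cl)c2)c1`, gives 2500 nM in this assay, the lowest of the three numbers, with compound 1 nearest and compound 2 furthest from it; how the core of compound 3 differs from the core of compound 1 is not broken down here. Compound 4, built as `Oc1cccc(-c2cc(-c3ccco3)nc(-c3ccccc3Cl)c2)c1`, has not yet been measured in this assay. It arises from compound 3 by furan-2-yl in place of thiophen-3-yl on an aromatic carbon, the same kind of change as that from compound 1 to compound 2, though not the same, since around the place compound 3 carries a 2-chlorophenyl group and a 3-hydroxyphenyl group where compound 1 carries a 3-chlorophenyl group and a 4-hydroxyphenyl group. Because the earlier step was a 1.4-fold higher number from compound 1 to compound 2 (0.14 log units; within the scatter), compound 4 is expected to sit close to compound 3, with a step of about a 1.4-fold higher number from compound 3 to compound 4 (0.15 log units; within the scatter) in this assay. Compound 4 is therefore estimated at 3500 nM in this assay, between 1800 nM and 7000 nM.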

Compound 4, half-maximal inhibitory concentration: 2230 nM
For compound 4 the middle estimate is 1.6-fold (0.20 log units) above the measured one, and the stated range covers the measured number.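

In this assay, furan-2-yl in place of thiophen-3-yl next to the ring nitrogen gave a 1.1-fold lower number from compound 3 to compound 4 (0.05 log units; within the scatter), so on this second core too the exchange left the number within the scatter. Set beside the earlier step, the two cores show no difference that can be told from the scatter: the same change on two cores in this assay, a 1.4-fold higher number (0.14 log units; within the scatter) from compound 1 to compound 2 and a 1.1-fold lower number (0.05 log units; within the scatter) from compound 3 to compound 4, 1.6-fold (0.19 log units) apart, within the scatter of two such steps This shows that, for these two pairs, the exchange carried from one core to the other without a measurable effect on either, but two pairs do not show that it would hold on any further core of the series, and they give no reason for the result.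

The compounds shown carry only thiophen-3-yl or furan-2-yl at this place, so it remains open whether an amine or a carboxylic acid there would move the number. Compound 3 also differs from compound 1 in both the chlorophenyl and the hydroxyphenyl group at once, which leaves the share of each open.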